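Furan-2-yl carbonyl in place of propyl carbonyl

The source may report more compounds than this note shows. Statements on the series, on what has been measured and on what is new or still open speak of the compounds shown alone.

Three members of the series have been run in an ADME assay on Caco-2 cells (Homo sapiens) for permeability, in the apical to basolateral direction; on this read-out lower numbers stand for lower permeability and higher numbers for higher permeability. Compound 1 `Cn1cncc1CN1CC(N(CC2CCN(C(=O)Nc3ccc(Br)cc3)CC2)S(=O)(=O)c2ccccn2)Cc2cc(C#N)ccc21` gives 0.6 10^-6 cm/s. Compound 2 `Cn1cncc1CN1CC(N(CC2CCN(C(=O)NC(C)(C)C)CC2)S(=O)(=O)c2ccccn2)Cc2cc(C#N)ccc21` gives 0.6 10^-6 cm/s. Compound 3 `CCCC(=O)N1CCC(CN(C2Cc3cc(C#N)ccc3N(Cc3cncn3C)C2)S(=O)(=O)c2ccccn2)CC1` gives 0.5 10^-6 cm/s, the lowest of the three numbers shown, though its gaps to the other two fall inside the scatter: a 1.2-fold lower number from compound 1 to compound 3 (0.08 log units; within the scatter) and a 1.2-fold lower number from compound 2 to compound 3 (0.08 log units; within the scatter). Exchanging the substituted amino groups at the carbonyl carbon for propyl, as in those two steps, did not move the read-out, and neither did no change at the digits printed from compound 1 to compound 2 (within the scatter).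

Compound 4 `Cn1cncc1CN1CC(N(CC2CCN(C(=O)c3ccco3)CC2)S(=O)(=O)c2ccccn2)Cc2cc(C#N)ccc21` carries the change (furan-2-yl in place of propyl on a carbonyl carbon); cut one bond further out, propylcarbonyl becomes (furan-2-yl)carbonyl. Among the compounds with values here, no measured step places a five-membered aromatic ring with 1 hetero atom at this carbonyl carbon, so the only guide is that every exchange made there so far stayed within the scatter. The step is therefore expected to be a 1.2-fold higher number from compound 3 to compound 4 (0.08 log units; within the scatter), with no shift beyond the scatter. Compound 4 is estimated at 0.6 10^-6 cm/s, within the range 0.3 10^-6 cm/s to 1.2 10^-6 cm/s.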

Compound 4, apparent permeability: 0.5 10^-6 cm/s
Compound 4: the middle estimate sits 1.2-fold (0.08 log units) above what was measured, and the stated range covers the measured number.
By their numbers in this assay, from the lowest: compounds 3, 4, 1 and 2 (each within the scatter of the next).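

In this assay, furan-2-yl at this carbonyl carbon leaves the read-out where propyl had it (no change at the digits printed from compound 3 to compound 4 (within the scatter)), so a five-membered aromatic ring with 1 hetero atom now joins the groups that stay within the scatter at this place. The same holds against (tert-butyl)amino (a 1.2-fold lower number from compound 2 to compound 4 (0.08 log units; within the scatter)) and (4-bromophenyl)amino (a 1.2-fold lower number from compound 1 to compound 4 (0.08 log units; within the scatter)), so alkyl, aromatic and substituted amino groups on this carbonyl carbon all give numbers within the scatter of each other, and no compound shown goes against this. Nothing available gives a reason for this lack of movement.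

Open, from the compounds shown here alone, is whether any group at this carbonyl carbon shifts the read-out beyond the scatter, for example a carboxylic acid, a basic amine or a longer chain. Also open, going by these compounds, is whether a change elsewhere on the shared core would do so.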